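The source may hold more compounds than are shown below. What is called first, only, known or untested is meant among the compounds shown, and "the series" means these compounds.

Of the compounds shown here, two have been measured so far in an assay on isolated protein for inhibition of protein kinase C theta type (Homo sapiens), read by TR-FRET, with a stated time of 2 h; a lower number here means a stronger inhibitor, a higher number a weaker inhibitor. Compound 1 `N#Cc1cnc(NCc2cnccc2C(F)(F)F)cc1NC[C@H]1C[C@@H](O)C1` gives 300 nM, and compound 2 `N#Cc1cnc(NCc2ccccc2C(F)(F)F)cc1N[C@H]1CC[C@@H](O)CC1` gives 140 nM. Of these two numbers, compound 1 holds the higher one, so it is the weaker inhibitor of the pair, and the gap to compound 2 is wider than the usual scatter of repeated runs. The two differ in more than one place, so nothing can be read from that gap about any single change.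

Compound 3 `N#Cc1cnc(NCc2cnccc2C(F)(F)F)cc1N[C@H]1CC[C@H](O)CC1` has not yet been measured. It differs from compound 1 in a single place: 4-hydroxycyclohexyl in place of (3-hydroxycyclobutyl)methyl on a nitrogen on an aromatic ring. The ring that enters is the same kind of ring that compound 2 carries on its nitrogen, while the other parts of compound 3 stay as in compound 1.

Without a measured pair that isolates this change, the size of the step is uncertain. Compound 3 is estimated to land at 180 nM, with a plausible range from 70 nM to 450 nM, which would mean an expected step of a 1.7-fold lower number from compound 1 to compound 3 (0.22 log units; within the scatter) of modest size toward stronger inhibition, though a result within the scatter of compound 1 would not be surprising.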

Compound 3, half-maximal inhibitory concentration: 350 nM
Compound 3: the middle estimate sits 1.9-fold (0.29 log units) below what was measured; low and high end bracket the measured number.
By their numbers in this assay, from the lowest: compound 2; then compounds 1 and 3 (each within the scatter of the next).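

In this assay, among the compounds shown here, swapping (3-hydroxycyclobutyl)methyl for 4-hydroxycyclohexyl gives a 1.2-fold higher number from compound 1 to compound 3 (0.07 log units; within the scatter), and this is the one change at this position that can be read on its own. A one-carbon link and a four-membered ring give way to a six-membered ring, yet the result stays within the scatter, so this assay does not tell these two hydroxyl-bearing groups apart on the core of compound 1. Nothing measured here offers an explanation for this result.

As far as these compounds go, both groups carry a hydroxyl group, so it remains open how the number would respond to a plain cyclohexyl, with no hydroxyl group, or to 4-aminocyclohexyl, with an amine in its place. A single pair also cannot show whether the same swap would read alike on a different core, or whether the other spatial arrangement of the hydroxyl group on the six-membered ring would matter.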